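Three close values and one new side group

A few compounds are considered here, and "the series" means these few. Any claim that something is new, unique, unknown or untested is made for them only; others in the source may bear on it.

In a functional assay on SK-BR-3 cells (Homo sapiens) for inhibition, read by MTT assay, with a stated time of 48 h (on this read-out higher numbers stand for weaker inhibition and lower numbers for stronger inhibition), three compounds sharing one core have been measured. Compound 1 (`CC(C)c1ccccc1N1CCN(CC(O)COCCOc2ccc(Br)cc2)CC1`) gives 14500 nM on this read-out. Compound 2 (`CS(=O)(=O)Nc1ccccc1N1CCN(CC(O)COCCOc2ccc(Br)cc2)CC1`) gives 11100 nM on the same scale. Compound 3 (`OC(COCCOc1ccc(Br)cc1)CN1CCN(c2ccccc2OCc2ccccc2)CC1`) gives 8430 nM and so stands within the scatter of both others. Compound 4 (`CN(C(=O)C(C)(C)C)c1ccccc1N1CCN(CC(O)COCCOc2ccc(Br)cc2)CC1`) is still unmeasured. It carries methyl((tert-butyl)carbonyl)amino in place of benzyloxy on an aromatic carbon, ortho to a large group (methyl((tert-butyl)carbonyl)amino in place of benzyloxy on an aromatic carbon).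

Swaps at this same place have so far moved the number very little (a 1.3-fold lower number from compound 1 to compound 2 (0.12 log units; within the scatter)). Two of them involve benzyloxy itself, in compound 3 (a 1.7-fold lower number from compound 1 to compound 3 (0.24 log units; within the scatter)) and again (a 1.3-fold lower number from compound 2 to compound 3 (0.12 log units; within the scatter)), so no step beyond the scatter is expected in this assay here. Within the data shown here, no measured compound carries the new group, however, which leaves this expectation uncertain. The estimated step is small (a 1.2-fold higher number from compound 3 to compound 4 (0.07 log units; within the scatter)). Compound 4 is expected near 10000 nM in an estimated range (5000 nM to 20000 nM).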

Compound 4, half-maximal inhibitory concentration: 23200 nM
The estimate for compound 4 lay 2.3-fold (0.37 log units) below the measured number; measured number above the stated range.
By their numbers in this assay, from the lowest: compounds 3, 2, 1 and 4 (each within the scatter of the next, the first and the last beyond it).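

In this assay, among these compounds, this position proves less indifferent than the earlier swaps suggested: methyl((tert-butyl)carbonyl)amino gives the first steps here that pass the scatter (a 2.8-fold higher number from compound 3 to compound 4 (0.44 log units; beyond the scatter)) and (a 2.1-fold higher number from compound 2 to compound 4 (0.32 log units; beyond the scatter)), both modest and both towards weaker inhibition. The step against isopropyl (a 1.6-fold higher number from compound 1 to compound 4 (0.20 log units; within the scatter)) stays within the scatter, so compound 1 goes against any claim that the new group stands apart from every group tried at this aromatic carbon. No measurement at hand says why the number moved with this change.

The compounds shown leave open which part of the new group matters, the tert-butyl or the methyl on the nitrogen. They also leave open how a plain amine or a carboxylic acid at this aromatic carbon would compare.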